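The source may hold more compounds than are shown below. What is called first, only, known or untested is meant among the compounds shown, and "the series" means these compounds.

Compound 1, `O=[N+]([O-])c1cc(C(F)(F)F)ccc1S(=O)(=O)Nc1ccc(Oc2ccnc3ccccc23)cc1`: > 40000 nM in a functional assay on PLC-PRF-5 cells (Homo sapiens) for inhibition; on this read-out higher numbers stand for weaker inhibition and lower numbers for stronger inhibition
Compound 2, `O=[N+]([O-])c1cc(C(F)(F)F)ccc1S(=O)(=O)Nc1ccc(Oc2ccnc3c([N+](=O)[O-])cccc23)cc1`: > 40000 nM
Compound 3, `O=C(Nc1ccc(Oc2ccnc3ccccc23)cc1)c1cc(C(F)(F)F)ccc1F`: 21100 nM

The value of compound 1 is a limit of this assay, not a number. The value of compound 2 is likewise a limit. Compound 2 differs from compound 1 by nitro in place of hydrogen on an aromatic carbon; the step that the two limits leave unreadable from compound 1 to compound 2 cannot be read because both ends sit at the limit of > 40000 nM in this assay, at which 2 of the 3 values shown sit. Compound 3 rests on a different core than compound 1; the difference between the two cores is not broken down here. Compound 4, `O=C(Nc1ccc(Oc2ccnc3c([N+](=O)[O-])cccc23)cc1)c1cc(C(F)(F)F)ccc1F`, has not yet been measured in this assay; it differs from compound 3 by nitro in place of hydrogen on an aromatic carbon, the same change as from compound 1 to compound 2. Since the measured step gives no readable size, the expectation for compound 4 rests on compound 3 alone, with 21100 nM as the anchor. The step of a 1.2-fold higher number from compound 3 to compound 4 (0.07 log units; within the scatter) is expected to be small. Compound 4 is therefore estimated at 25000 nM, within 8000 nM to 40000 nM.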

Compound 4, half-maximal inhibitory concentration: > 40000 nM
Compound 4: a limit, no number; the forecaster's own chance of this, stated with the estimate: 40%; middle value at least 1.6-fold (0.20 log units) from the limit.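

Carried to a second core, nitro in place of hydrogen on an aromatic carbon gives an at least 1.8-fold higher number from compound 3 to compound 4 (0.27 log units; that floor lies within the scatter). In this assay, compound 4 gives > 40000 nM, which is a limit and not a number. The same change on the core of compound 1 cannot be read, so its size cannot be compared between the two cores, and these compounds do not show whether it carries over with the same effect: the limit of > 40000 nM in this assay, at which 3 of the 4 values shown sit.

Still open, from the compounds shown here alone, is how an amine or a nitrile at the same aromatic carbon would compare with compound 3, which gives 21100 nM. Also open, going by these compounds, is what a carboxylic acid in place of the trifluoromethyl would do on this core.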